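Halogen on the pendant phenyl of the shared core

A few compounds are considered here, and "the series" means these few. Any claim that something is new, unique, unknown or untested is made for them only; others in the source may bear on it.

Compound 1 `COc1cc2c(Oc3ccc(NC(=O)c4nn(-c5ccccc5)c(=O)c5ccccc45)cc3F)ccnc2cc1OCCCN1CCCC1` carries an unsubstituted phenyl on the shared core. In a functional assay on MDA-MB-231 cells (Homo sapiens) for cytotoxicity, read by MTT assay, with a stated time of 72 h (a higher number here means a weaker inhibitor, a lower number a stronger inhibitor), compound 1 gives 1130 nM, the highest of the two numbers recorded so far. Its nearest neighbour is compound 2 `COc1cc2c(Oc3ccc(NC(=O)c4nn(-c5cccc(F)c5)c(=O)c5ccccc45)cc3F)ccnc2cc1OCCCN1CCCC1`, which in this assay gives 880 nM. Among the measured compounds shown here, the only measured step, a 1.3-fold lower number from compound 1 to compound 2 (0.11 log units; within the scatter), lies within the scatter. Compound 3 `COc1cc2c(Oc3ccc(NC(=O)c4nn(-c5ccccc5Br)c(=O)c5ccccc45)cc3F)ccnc2cc1OCCCN1CCCC1` differs from compound 1 by bromo in place of hydrogen on an aromatic carbon. For the measured compounds named here, the fluoro step bears on this change only as another halogen entering the same phenyl ring; no measured step reaches beyond the scatter, and no bromo analogue has been measured. For compound 3 the expected step is therefore a 1.0-fold lower number from compound 1 to compound 3 (0.01 log units; within the scatter), with no movement beyond the scatter anticipated. The estimate for compound 3 in this assay is 1100 nM, with a range from 400 nM to 3200 nM to allow for the unmeasured bromo and its place ortho to a large group.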

Compound 3, half-maximal inhibitory concentration: 1020 nM
Compound 3: middle estimate off by 1.1-fold (0.03 log units), on the high side; low and high end bracket the measured number.
By their numbers in this assay, from the lowest: compounds 2, 3 and 1 (each within the scatter of the next).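

Bromo on an aromatic carbon, ortho to a large group, adds a second halogen and a second place on the pendant phenyl, and in this assay this step also stays within the scatter (a 1.1-fold lower number from compound 1 to compound 3 (0.04 log units; within the scatter)). The two halogenated phenyl groups cannot be told apart either (a 1.2-fold higher number from compound 2 to compound 3 (0.06 log units; within the scatter)), so neither halogen separates from the unsubstituted phenyl of compound 1 or from the other. The data offer no measured basis for explaining this reading.

Still open, on these data alone, is whether any group on this phenyl ring moves the number beyond the scatter, for example an amine, a carboxylic acid or a methoxy group in the place taken by bromo in compound 3. Also open, as far as these compounds go, is how bromo would read in the place held by fluoro in compound 2.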